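A few compounds are considered here, and "the series" means these few. Any claim that something is new, unique, unknown or untested is made for them only; others in the source may bear on it.

Compound 1 `O=C(CSc1snnc1-c1ccc(Br)cc1Br)Nc1ccccc1` gives 24800 nM in an ADME assay on MT4 cells (Homo sapiens) for cytotoxicity, read by MTT assay, with a stated time of 5 days; a higher number here means that more compound is tolerated, a lower number that less compound is tolerated. Compound 3 `Cc1ccc2sc(NC(=O)CSc3snnc3-c3ccc(Br)cc3Br)nc2c1` gives 23600 nM there. Compound 2 `COC(=O)c1ccsc1NC(=O)CSc1snnc1-c1ccc(Br)cc1Br` is recorded only at a limit of this assay, > 227000 nM, so its own number is not known. Going by the values given here, the step of an at least 9.1-fold higher number from compound 1 to compound 2 (0.96 log units; beyond the scatter) is the one measured change bearing on what follows, and it is at least modest. Compound 4 `Cc1ccccc1NC(=O)CSc1snnc1-c1ccc(Br)cc1Br` differs from compound 2 by 2-methylphenyl in place of 3-(methoxycarbonyl)thiophen-2-yl on an amide-type nitrogen, a change that largely reverses that step, leaving a group close to the phenyl of compound 1. A shift back toward the values of compound 1 and compound 3 is therefore expected, in the direction of a lower number. Compound 4 is estimated at 28000 nM, with a range from 10000 nM to 90000 nM, the step of an at least 8.1-fold lower number from compound 2 to compound 4 (0.90 log units; beyond the scatter) being the expected size.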

Compound 4, half-maximal cytotoxic concentration: 202000 nM
Compound 4: middle estimate off by 7.2-fold (0.86 log units), on the low side; measured number above the stated range.
By their numbers in this assay, from the lowest: compounds 3 and 1 (each within the scatter of the next); then compound 4. At a limit, above all of these: compound 2.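

Methyl in place of hydrogen on an aromatic carbon gives an 8.1-fold higher number from compound 1 to compound 4 (0.91 log units; beyond the scatter), so at this place on the amide-type nitrogen, 2-methylphenyl does not behave like the phenyl of compound 1. Putting 2-methylphenyl in place of 3-(methoxycarbonyl)thiophen-2-yl gives an at least 1.1-fold lower number from compound 2 to compound 4 (0.05 log units; that floor lies within the scatter), so no real drop is shown, and a high number does not require the thiophene group. Compound 2 has a limit rather than a number: the limit of > 227000 nM in this assay, at which 1 of the 4 values shown sits.

As far as these compounds go, how far compound 2 truly lies from compound 4 remains open. So does what an ethyl group or a chlorine atom in place of the methyl would give.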